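Series notes: lengthening the chain on the aromatic nitrogen

The source may hold more compounds than are shown below. What is called first, only, known or untested is meant among the compounds shown, and "the series" means these compounds.

Compound 1 `Cc1n[nH]c(-c2ccccc2NCC2=NCCN2)n1` and compound 2 `Cn1nccc1-c1ccccc1NCC1=NCCN1` share one core. Within the data shown here, in an in vitro functional assay on cells (Fibroblast) for agonist activity at Alpha-1D adrenergic receptor (Homo sapiens) (on this read-out higher numbers stand for an effect only at larger amounts of compound and lower numbers for an effect already at smaller amounts), the single measured step is a step that the two limits leave unreadable from compound 1 to compound 2. For compound 1 the value in this assay is a limit of the assay, < 5020 nM. For compound 2 the value in this assay is also a limit of the assay, < 100000 nM, so compound 2 stands only at a limit. Compound 3 `CCCn1nccc1-c1ccccc1NCC1=NCCN1` differs from compound 2 by ethyl in place of hydrogen on a saturated chain carbon bound to an aromatic nitrogen. Among the measured compounds shown here, no measured step bears on this change, and no direction beyond the scatter is expected. For compound 3 the estimated step is a step that the limit leaves unreadable from compound 2 to compound 3. Compound 3 is expected to give 10000 nM, within 800 nM to 100000 nM.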

Compound 3, half-maximal effective concentration: < 100000 nM
Compound 3 was reported as a limit (the forecaster's own chance of this, stated with the estimate: 50%); the middle value lies beyond the limit too.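

Compound 2 and compound 3 both stand only at a limit of the assay, so no step can be read between them: the limit of < 100000 nM in this assay, at which 2 of the 3 values shown sit.

Going by these compounds, whether ethyl in place of hydrogen on a saturated chain carbon bound to an aromatic nitrogen shifts the half-maximal effective concentration in this assay remains open.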